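Exchanging a charged ring for morpholin-4-yl on compound 2

This account rests on a few compounds, and the source may have more. Where it says the series, first, only, none or still open, it means among the compounds named here.

In a functional assay (aorta) with Rattus norvegicus as the target (on this read-out higher numbers stand for an effect only at larger amounts of compound and lower numbers for an effect already at smaller amounts), two compounds on the shared core have been measured so far. Compound 1 (`CNC(=N)Nc1nc(-c2ccc(OC)cc2)c(-c2ccc(OC)cc2)s1`) gives 1.2 uM as its value, and compound 2 (`COc1ccc(-c2nc(/N=C(\N)[N+]3(C)CCCCC3)sc2-c2ccc(OC)cc2)cc1`) stands highest of the two with 21 uM as its value.

Compound 3 (`COc1ccc(-c2nc(/N=C(\N)N3CCOCC3)sc2-c2ccc(OC)cc2)cc1`) has not yet been measured. Its change from compound 2 is a group of 6 heavy atoms (4 carbon, 1 nitrogen, 1 oxygen; one six-membered non-aromatic ring with 2 hetero atoms) in place of a group of 7 heavy atoms (6 carbon, 1 nitrogen; one six-membered non-aromatic ring with 1 hetero atom), on a carbon with a double bond to nitrogen and with it a group of net charge +1 gives way to one with no net charge. Within the data shown here, no measured step covers this exchange directly. Among the measured compounds shown here, the only step available is an 18-fold higher number from compound 1 to compound 2 (1.24 log units; beyond the scatter) and it bears on the question loosely, as it replaced a group with no ring by a larger group with a six-membered non-aromatic ring. Compound 3 keeps a six-membered non-aromatic ring, so a move of that size is not expected. The expected change is small and towards a lower number, an estimated 1.9-fold lower number from compound 2 to compound 3 (0.28 log units; within the scatter) in this assay with wide uncertainty. For compound 3 the estimated value is 11 uM with an expected range from 3 uM to 35 uM in this read-out.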

Compound 3, concentration for half-maximal effect: 66 uM
For compound 3 the middle estimate is 6.0-fold (0.78 log units) below the measured one; measured number outside the range, above it.
By their numbers in this assay, from the lowest: compound 1; then compound 2; then compound 3.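

In this assay, among these compounds, replacing the charged ring with morpholin-4-yl on the carbon with a double bond to nitrogen gives a 3.1-fold higher number from compound 2 to compound 3 (0.50 log units; beyond the scatter), so this position responds to a change within the six-membered ring and not only to the arrival of a ring, the only kind of change covered before. Losing the net charge did not bring the number back towards that of compound 1: the exchange moved it further away, and the comparison of the uncharged ring group with the open group of compound 1 now gives a 55-fold higher number from compound 1 to compound 3 (1.74 log units; beyond the scatter), so among these three compounds both ring-bearing groups stand above compound 1, with none going against this. No measurement given here explains why morpholin-4-yl sits higher than the charged ring.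

The compounds shown leave open how much of the step from the charged ring to morpholin-4-yl belongs to the loss of charge and how much to the ring oxygen, as the two change together. An uncharged piperidin-1-yl group at this place would separate the two, and a dimethylamino group would test whether any ring is needed there at all.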